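Fluoro addition on the anilide ring: clearance notes

This account rests on a few compounds, and the source may have more. Where it says the series, first, only, none or still open, it means among the compounds named here.

compound 1 (`CN1C[C@H](C(=O)Nc2ccccc2)[C@@H](c2ccc(/C=C/C(=O)Nc3ccccc3N)cc2)C1`) gives 7 mL/min/kg
compound 2 (`CC(C)c1ccc(NC(=O)[C@H]2CN(C)C[C@@H]2c2ccc(/C=C/C(=O)Nc3ccccc3N)cc2)cc1`) gives 10 mL/min/kg
compound 3 (`CN1C[C@H](C(=O)Nc2ccccc2F)[C@@H](c2ccc(/C=C/C(=O)Nc3ccccc3N)cc2)C1`) gives 10 mL/min/kg

In an in vitro ADME assay on microsomes from liver (Homo sapiens) for pharmacokinetics, read by LC-MS, with a stated time of 10 min, tested at 1 uM (on this read-out higher numbers stand for fast clearance and lower numbers for slow clearance), compound 3 stands at 10 mL/min/kg level with compound 2 and within the scatter of compound 1. Compound 4 (`CN1C[C@H](C(=O)Nc2ccc(F)cc2F)[C@@H](c2ccc(/C=C/C(=O)Nc3ccccc3N)cc2)C1`) differs from compound 3 by one change (fluoro in place of hydrogen on an aromatic carbon), a fluoro on an aromatic carbon, meta to a fluoro group and para to a large group. The nearest measured precedent is the same replacement (a 1.4-fold higher number from compound 1 to compound 3 (0.15 log units; within the scatter)), which stayed within the scatter, as did the isopropyl replacement (a 1.4-fold higher number from compound 1 to compound 2 (0.15 log units; within the scatter)). No step beyond the scatter is therefore expected (no change at the digits printed from compound 3 to compound 4 (within the scatter)). Compound 4 is estimated at 10 mL/min/kg within an expected range (6 mL/min/kg to 17 mL/min/kg).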

Compound 4, clearance: 12 mL/min/kg
Compound 4: the middle estimate sits 1.2-fold (0.08 log units) below what was measured; the measured number falls inside the stated range.
By their numbers in this assay, from the lowest: compounds 1, 2, 3 and 4 (each within the scatter of the next).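

In this assay, a fluoro on the aromatic carbon para to a large group and meta to a fluoro group gives a 1.2-fold higher number from compound 3 to compound 4 (0.08 log units; within the scatter), so this position accepts the added fluoro with no step beyond the scatter. The 2,4-difluorophenyl group also stays within the scatter as a replacement for phenyl, with a 1.7-fold higher number from compound 1 to compound 4 (0.23 log units; within the scatter), and for 4-isopropylphenyl, with a 1.2-fold higher number from compound 2 to compound 4 (0.08 log units; within the scatter). No supporting data bear on what lies behind these small steps.

As far as these compounds go, whether an amine or a carboxylic acid at this position would give a step beyond the scatter remains open.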